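The compounds below may be only part of what the source reports. "The series", "measured", "known", "first", "only" and "open" are said of these compounds alone.

In a functional assay on the whole organism (strain Sprague-Dawley) for inhibition, with Rattus norvegicus as the target, with a stated time of 10 min (on this read-out lower numbers stand for an effect already at smaller amounts and higher numbers for an effect only at larger amounts of compound), compound 1 `CCOc1ccccc1-c1ncc(C(=O)O)c(=O)[nH]1` gives 0.5 mg/kg, while compound 2 `CCOc1ccc(S(=O)(=O)N(CC)CC)cc1-c1ncc(C(=O)O)c(=O)[nH]1` gives 40 mg/kg, the higher of the two numbers. Going by the values given here, the only measured step, an 80-fold higher number from compound 1 to compound 2 (1.90 log units; beyond the scatter), is large and came with diethylsulfamoyl in place of hydrogen on an aromatic carbon. Compound 3 `CCOc1ccc(S(=O)(=O)N(C)C(C)C)cc1-c1ncc(C(=O)O)c(=O)[nH]1` has the same atoms joined differently, with isopropyl(methyl)amino in place of diethylamino on a sulfonyl sulfur. Among the compounds with values here, no measured step tests this swap, and that large step shows only what adding the whole group did. The expected change is therefore none beyond the scatter, an estimated 1.1-fold lower number from compound 2 to compound 3 (0.06 log units; within the scatter). For compound 3 the estimated value is 35 mg/kg, with an expected range of 12 mg/kg to 100 mg/kg.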

Compound 3, dose for 50% inhibition: > 10 mg/kg
Compound 3: only a limit was reported; the forecaster's own chance of this, stated with the estimate: 10%; the middle value lies beyond the limit too.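

Compound 3 gave no number, only a limit, in this assay: the limit of > 10 mg/kg in this assay, at which 1 of the 3 values shown sits. Even so, isopropyl(methyl)sulfamoyl in place of hydrogen on an aromatic carbon goes with an at least 20-fold higher number from compound 1 to compound 3 (1.30 log units; beyond the scatter), so the large step is not confined to diethylsulfamoyl: both sulfamoyl groups shown go with higher numbers than compound 1.

As far as these compounds go, the step between the two sulfamoyl compounds cannot be read, so the effect of isopropyl(methyl)amino in place of diethylamino stays open. Also open, from the compounds shown here alone, is how dimethylamino or piperidine on the sulfonyl sulfur would compare.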